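This account rests on a few compounds, and the source may have more. Where it says the series, first, only, none or still open, it means among the compounds named here.

Compound 1 `CCC(=O)NNC(=O)c1csc2ncc(-c3ccc(C)cc3)n12`: 7340 nM
Compound 2 `CCC(=O)NNC(=O)c1csc2ncc(-c3ccc(OC)cc3)n12`: 45800 nM
Compound 3 `CC(=O)NNC(=O)c1csc2ncc(-c3ccc(Br)cc3)n12`: 3480 nM

All three values come from a functional assay on HepG2 cells (Homo sapiens) for antiproliferative activity, read by MTT assay, with a stated time of 72 h; on this read-out lower numbers stand for stronger inhibition and higher numbers for weaker inhibition. Compound 3, at 3480 nM, has the lowest number of the three, and its gaps to both of the others lie beyond the usual scatter. Compound 4 `CCC(=O)NNC(=O)c1csc2ncc(-c3ccc(Br)cc3)n12` differs from compound 3 in a single place: methyl in place of hydrogen on a saturated chain carbon bound to a carbonyl carbon. This change turns acetyl into propanoyl. Going by the values given here, no measured step changes this chain. Among the compounds with values here, the only step available, a 6.2-fold higher number from compound 1 to compound 2 (0.80 log units; beyond the scatter), comes with methoxy in place of methyl on an aromatic carbon, so it bears on this change only indirectly. It shows that one small swap can shift the number modestly in this series, which argues for a wide range. With no measured evidence for a direction, no shift beyond the scatter is expected. The expected step is a 1.1-fold higher number from compound 3 to compound 4 (0.04 log units; within the scatter). For compound 4 the estimated value is 3800 nM, with an expected range of 1400 nM to 10000 nM.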

Compound 4, half-maximal inhibitory concentration: 19200 nM
The estimate for compound 4 lay 5.1-fold (0.70 log units) below the measured number; measured number outside the range, above it.
By their numbers in this assay, from the lowest: compound 3; then compound 1; then compound 4; then compound 2.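

In this assay the chain bound to the carbonyl carbon proves to matter: turning acetyl into propanoyl gives a 5.5-fold higher number from compound 3 to compound 4 (0.74 log units; beyond the scatter) and shows that one added methyl at this position can weaken inhibition. With propanoyl held fixed, the aromatic group can now be compared across three compounds: bromo in place of methyl gives a 2.6-fold higher number from compound 1 to compound 4 (0.42 log units; beyond the scatter) and bromo in place of methoxy gives a 2.4-fold lower number from compound 2 to compound 4 (0.38 log units; beyond the scatter) so that, among these propanoyl compounds, bromo falls in the middle. Nothing measured here explains any of these steps.

As far as these compounds go, whether a longer chain such as butanoyl, or a chain carrying an amine, would raise the number further remains open. So does whether adding the same methyl to the acetyl chain has a similar effect with methyl or methoxy in place of bromo on the aromatic carbon.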